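Swapping fluoro for methoxy on the outer phenyl ring

A few compounds are considered here, and "the series" means these few. Any claim that something is new, unique, unknown or untested is made for them only; others in the source may bear on it.

Of the compounds shown here, two sharing one core have been tested in a functional assay on HeLa cells (Homo sapiens) for cytotoxicity, read by MTT assay, with a stated time of 2 days, tested at 0.1 uM; on this read-out higher numbers stand for a weaker effect at the one concentration tested and lower numbers for a stronger effect. Compound 1 `CC(=O)c1cc(-c2ccccc2)cc2cc(-c3ccc(F)cc3)[nH]c12` gives 91.1%. Compound 2 `CC(=O)c1cc(-c2ccc(F)cc2)cc2cc(-c3ccc(F)cc3)[nH]c12`, carrying fluoro in place of hydrogen on an aromatic carbon, gives 90.1%, and the step of a number 1 percentage points lower from compound 1 to compound 2 (within the scatter). Compound 2 thus holds the lowest of the two numbers, with compound 1 nearest to it and within the scatter.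

Compound 3 `COc1ccc(-c2cc(C(C)=O)c3[nH]c(-c4ccc(F)cc4)cc3c2)cc1` has not yet been measured. Its difference from compound 2 is methoxy in place of fluoro on an aromatic carbon, that is, 4-fluorophenyl becomes 4-methoxyphenyl. Among the measured compounds shown here, the only step that bears on this is the one from compound 1 to compound 2, which altered this very aromatic carbon and stayed within the scatter. On that basis no movement beyond the scatter is expected, so compound 3 is estimated at 89% with a range from 78% to 98%, meaning an expected step of a number 1.1 percentage points lower from compound 2 to compound 3 (within the scatter).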

Compound 3, a percentage reported as activity, at one concentration (the size of the read-out at that concentration, not a potency): 74.5%
For compound 3 the middle estimate is 14.5 percentage points above the measured one; measured number outside the range, below it.
By their numbers in this assay, from the lowest: compound 3; then compounds 2 and 1 (each within the scatter of the next).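

The earlier pair suggested that this aromatic carbon, para to a large group, might tolerate change without consequence, yet in this assay 4-methoxyphenyl in place of 4-fluorophenyl gives a number 15.6 percentage points lower from compound 2 to compound 3 (beyond the scatter), so what sits here does matter. Methoxy in place of hydrogen likewise gives a number 16.6 percentage points lower from compound 1 to compound 3 (beyond the scatter), whereas fluoro stayed within the scatter of hydrogen, so among these three compounds the stronger effect appears only with methoxy. Nothing available here explains this difference.

The compounds shown leave open whether a hydroxyl, an amine such as dimethylamino or a longer chain such as ethoxy at this carbon would match methoxy. They also leave open whether the stronger effect would hold at other concentrations or with methoxy elsewhere on this ring.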